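Trading a Triazole for an Imidazole in Two Cores

A few compounds are considered here, and "the series" means these few. Any claim that something is new, unique, unknown or untested is made for them only; others in the source may bear on it.

Four closely related compounds are compared here. Compound 1 `CCC(C)n1ncn(-c2ccc(N3CCN(c4ccc(OC[C@@H]5CO[C@@](Cn6cncn6)(c6ccc(Cl)cc6Cl)O5)nc4)CC3)cc2)c1=O` and compound 2 `CCC(C)n1ncn(-c2ccc(N3CCN(c4ccc(OC[C@@H]5CO[C@@](Cn6cncn6)(c6ccc(Cl)cc6Cl)O5)cn4)CC3)cc2)c1=O` are built from the same atoms joined differently; the difference between the two cores is not broken down here. In a physicochemical assay for solubility, read by HPLC, measured as thermodynamic solubility (on this read-out higher numbers stand for higher solubility and lower numbers for lower solubility), compound 1 gives 0.116 ug/mL, and compound 2 gives 0.114 ug/mL. These two numbers lie within the scatter of each other.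

Compound 3 `CCC(C)n1ncn(-c2ccc(N3CCN(c4ccc(OC[C@@H]5CO[C@@](Cn6ccnc6)(c6ccc(Cl)cc6Cl)O5)nc4)CC3)cc2)c1=O` is compound 1 with one change: 1H-imidazol-1-yl in place of 1H-1,2,4-triazol-1-yl on a saturated chain carbon bound to a saturated ring carbon The effect was a 56-fold higher number from compound 1 to compound 3 (1.75 log units; beyond the scatter). In this assay compound 3 gives 6.48 ug/mL, the highest of the three measured numbers.

Compound 4 `CCC(C)n1ncn(-c2ccc(N3CCN(c4ccc(OC[C@@H]5CO[C@@](Cn6ccnc6)(c6ccc(Cl)cc6Cl)O5)cn4)CC3)cc2)c1=O` has not yet been measured. It stands to compound 2 exactly as compound 3 stands to compound 1: 1H-imidazol-1-yl in place of 1H-1,2,4-triazol-1-yl on a saturated chain carbon bound to a saturated ring carbon The place of the change is the same in both pairs, so this is the same change made on the other core.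

Since compound 1 and compound 2 start from values within the scatter of each other, and the change has so far been seen once, with the result a 56-fold higher number from compound 1 to compound 3 (1.75 log units; beyond the scatter), a step of about the same size is expected on the other core. For compound 4 this means an expected step of a 53-fold higher number from compound 2 to compound 4 (1.72 log units; beyond the scatter). On that basis the estimated solubility of compound 4 is 6 ug/mL, with a plausible range from 2 ug/mL to 18 ug/mL.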

Compound 4, solubility: 2.94 ug/mL
The estimate for compound 4 lay 2.0-fold (0.31 log units) above the measured number; measured number inside the range.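

Swapping 1H-1,2,4-triazol-1-yl for 1H-imidazol-1-yl on a saturated chain carbon bound to a saturated ring carbon has now been seen on two cores, and in this assay both steps point the same way: a 56-fold higher number from compound 1 to compound 3 (1.75 log units; beyond the scatter) and a 26-fold higher number from compound 2 to compound 4 (1.41 log units; beyond the scatter) are each large and each lie beyond the scatter, so neither pair goes against the pattern. The change therefore carried over from one core to the other in direction and in broad size, although the printed step on the core of compound 2 is the smaller of the two, and two pairs of compounds cannot establish a rule for the whole series. The data show that the step occurs, but the structures and numbers here offer no measurement that explains it or accounts for the difference in printed size between the two cores.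

Among the compounds shown here, it remains open whether the same kind of step would appear on a core with a longer chain in place of the one shared by these compounds. As far as these compounds go, it is also open how a compound would read in this assay with an amine or a carboxylic acid at the place now held by 1H-imidazol-1-yl.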